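A few compounds are considered here, and "the series" means these few. Any claim that something is new, unique, unknown or untested is made for them only; others in the source may bear on it.

Measured compounds in this series:
compound 1 `CCOC(=O)CCO/N=C(/c1ccc(OC)c(OC)c1OC)c1cccc2ccccc12` — > 20000 nM
compound 2 `CCOC(=O)CO/N=C(/c1ccc(OC)c(OC)c1OC)c1cccc2ccccc12` — > 20000 nM
compound 3 `CCOC(=O)/C=C/CO/N=C(/c1ccc(OC)c(OC)c1OC)c1cccc2ccccc12` — > 20000 nM

In a functional assay on THP-1 cells (Homo sapiens) for inhibition, read by sulforhodamine B assay, with a stated time of 48 h (a lower number here means a stronger inhibitor, a higher number a weaker inhibitor), compound 1 gives > 20000 nM, which is a limit of the assay, not a number. Compound 2 also gives only the limit > 20000 nM. Compound 3 stands at the limit > 20000 nM as well. Because all three values sit at the limit of > 20000 nM in this assay, at which 3 of the 3 values shown sit, the steps a step that the two limits leave unreadable from compound 1 to compound 2, a step that the two limits leave unreadable from compound 1 to compound 3 and a step that the two limits leave unreadable from compound 2 to compound 3 cannot be sized.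

Compound 4 `COc1ccc(/C(=N/OCC(=O)O)c2cccc3ccccc23)c(OC)c1OC` differs from compound 3 by carboxy in place of 2-(ethoxycarbonyl)ethenyl on a saturated chain carbon bound to an oxygen on an unsaturated carbon. No measured step bears on this change; the three compounds shown only indicate that every variation tried so far in this assay remained at the limit. Compound 4 is therefore expected to remain at or beyond the limit, with the step that the limit leaves unreadable from compound 3 to compound 4 expected to be unreadable. The estimate for compound 4 is 30000 nM, range 10000 nM to 100000 nM.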

Compound 4, half-maximal inhibitory concentration: > 20000 nM
Compound 4 was reported as a limit (the forecaster's own chance of this, stated with the estimate: 85%); the middle value does not contradict the limit.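

Compound 4 gives > 20000 nM, which is a limit, so no step from compound 1, compound 2 or compound 3 to compound 4 can be read: the limit of > 20000 nM in this assay, at which 4 of the 4 values shown sit.

The compounds shown leave open which variation on the shared core, if any, would give a measurable value in this assay.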